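The source may report more compounds than this note shows. Statements on the series, on what has been measured and on what is new or still open speak of the compounds shown alone.

Three compounds share one core and differ only in the aryl group on the amine nitrogen in a ring. Compound 1 `CCC(C(=O)N1CCN(c2cccc(Cl)c2)CC1)N1C(=O)CCC1=O` carries a 3-chlorophenyl there; in a functional assay on the whole organism (strain Swiss) with Mus musculus as the target, in the maximal electroshock model, with a stated time of 2 h, at a dose of 300 mg/kg by the intraperitoneal route (on this read-out lower numbers stand for a weaker effect and higher numbers for a stronger effect at the one dose given), compound 1 gives 25%. Compound 3 `CCC(C(=O)N1CCN(c2ccc(Cl)cc2)CC1)N1C(=O)CCC1=O` carries a 4-chlorophenyl, and in this assay compound 3 gives 25%, so that no change at the digits printed from compound 1 to compound 3 (within the scatter). Compound 2 `CCC(C(=O)N1CCN(c2ccccc2F)CC1)N1C(=O)CCC1=O` carries a 2-fluorophenyl; in this assay compound 2 gives 0%, the lowest of the three numbers, with a number 25 percentage points lower from compound 1 to compound 2 (beyond the scatter) and a number 25 percentage points higher from compound 2 to compound 3 (beyond the scatter). Compound 4 `CCC(C(=O)N1CCN(c2ccccc2C(F)(F)F)CC1)N1C(=O)CCC1=O` has not yet been measured. It differs from compound 2 in one place: trifluoromethyl in place of fluoro on an aromatic carbon. Within the data shown here, no measured step bears on this change directly: each measured step exchanges one whole substituted phenyl for another, and none of them speaks to trifluoromethyl in place of fluoro. Among the measured compounds shown here, the only guide is that compound 2 sits at the bottom of the measured range while the two other ring patterns give higher numbers, and a percentage of this kind cannot fall below what compound 2 already shows. Compound 4 is therefore expected to show at most a small rise, a number 10 percentage points higher from compound 2 to compound 4 (within the scatter), most likely within the scatter. The estimate for compound 4 in this assay is 10%, with a range from 0% to 35%.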

Compound 4, a percentage reported as activity, at one dose (the size of the read-out at that dose, not a potency): 0%
Beside the measured number, compound 4's estimate is 10 percentage points above it; the measured number falls inside the stated range.
By their numbers in this assay, from the lowest: compounds 2 and 4 (each within the scatter of the next); then compounds 1 and 3 (each within the scatter of the next).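

In this assay, trifluoromethyl in place of fluoro on an aromatic carbon, ortho to a large group, gives no change at the digits printed from compound 2 to compound 4 (within the scatter), even though the entering group has 4 heavy atoms where the leaving group has 1. The earlier compounds shown here showed only one substituent at this place, so the bottom number could have belonged to fluoro alone; now two different groups there share the bottom of the range, with compound 4 at 0%, and the step gives no sign of a rise. The data offer no measured explanation for this result, and with both numbers at the bottom of the scale, the step cannot separate the two groups any further.

As far as these compounds go, whether a chloro or a methoxy group at this same place would reach the level of compound 3 at 25% remains open, and so does whether that higher number follows chloro itself or the place it occupies on the ring. From the compounds shown here alone, it is also open whether fluoro or trifluoromethyl at the ring places held by chloro in compound 1 and compound 3 would give a number above the bottom of the range.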